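The source may hold more compounds than are shown below. What is called first, only, known or untested is meant among the compounds shown, and "the series" means these compounds.

Compound 2, `Nc1ccccc1NC(=O)c1ccc(CSC(=S)N2CCN(Cc3ccncc3)CC2)cc1`, is the one to start from. In a functional assay on A-375 cells (Homo sapiens) for antiproliferative activity, read by CCK-8 assay, with a stated time of 72 h, tested at 8 uM (on this read-out higher numbers stand for a stronger effect at the one concentration tested and lower numbers for a weaker effect), compound 2 gives 89.5%, the highest of the three numbers as written, though compound 1, `CCN(Cc1ccncc1)C(=S)SCc1ccc(C(=O)Nc2ccccc2N)cc1`, gives 86.2% and compound 3, `Nc1ccccc1NC(=O)c1ccc(CSC(=S)N2CCCc3ccccc32)cc1`, gives 81.5%, both within the scatter of compound 2, so no real ranking can be drawn. Compound 4, `Nc1ccccc1NC(=O)c1ccc(CSC(=S)N2CCN(c3ccc(F)cc3)CC2)cc1`, differs from compound 2 in one place: 4-fluorophenyl in place of (pyridin-4-yl)methyl on an amine nitrogen in a ring. For the measured compounds named here, the only measured step, a number 4.7 percentage points lower from compound 1 to compound 3 (within the scatter), swaps a group on the thiocarbonyl carbon, a different place, so it bears on this change only loosely; it stayed within the scatter. Compound 4 is therefore expected to show no step beyond the scatter, a number 3.5 percentage points lower from compound 2 to compound 4 (within the scatter). Compound 4 is estimated at 86%, ranging from 76% to 94%.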

Compound 4, a percentage reported as inhibition, at one concentration (the size of the read-out at that concentration, not a potency): 76.3%
Compound 4: middle estimate off by 9.7 percentage points, on the high side; the measured number falls inside the stated range.
By their numbers in this assay, from the lowest: compounds 4, 3, 1 and 2 (each within the scatter of the next, the first and the last beyond it).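

In this assay this change gives a number 13.2 percentage points lower from compound 2 to compound 4 (beyond the scatter) and is the first step shown here to pass the scatter. The amine nitrogen in the ring is therefore a place where the choice of group can matter, even though both groups hold 7 heavy atoms and one six-membered aromatic ring. Nothing measured here explains the drop. Going by these compounds, the swap alters the ring nitrogen, the fluorine and the methyl link together, so their separate shares remain open. A plain phenyl or benzyl group on this nitrogen would help to pull them apart.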